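A few compounds are considered here, and "the series" means these few. Any claim that something is new, unique, unknown or untested is made for them only; others in the source may bear on it.

Measured compounds in a functional assay for antagonist activity at transient receptor potential cation channel subfamily V member 1 (Rattus norvegicus); on this read-out lower numbers stand for stronger inhibition and higher numbers for weaker inhibition:
compound 1, `Cc1cc(CNC(=O)CCc2ccc(C(C)(C)C)cc2)cc(C)c1NS(C)(=O)=O`, gives 620 nM;
compound 2, `Cc1cc(CNC(=O)CCc2ccc(C(C)(C)C)cc2)cc(Cl)c1NS(C)(=O)=O`, gives 100 nM;
compound 3, `Cc1cc(CNC(=S)CCc2ccc(C(C)(C)C)cc2)cc(C)c1NS(C)(=O)=O`, gives 2900 nM.

Compound 4, `Cc1cc(CNC(=S)CCc2ccc(C(C)(C)C)cc2)cc(Cl)c1NS(C)(=O)=O`, has not yet been measured. It differs from compound 3 by chloro in place of methyl on an aromatic carbon. The same change has already been made once, from compound 1 to compound 2, where chloro in place of methyl on an aromatic carbon gave a 6.2-fold lower number from compound 1 to compound 2 (0.79 log units; beyond the scatter). How the core of compound 3 differs from the core of compound 1 is not broken down here; compound 3 simply shows the highest number of the three. For the measured compounds named here, since the surroundings of the changed position are the same in both pairs, a step of similar size is expected for compound 4, namely a 5.8-fold lower number from compound 3 to compound 4 (0.76 log units; beyond the scatter), because a 6.2-fold lower number from compound 1 to compound 2 (0.79 log units; beyond the scatter) is the only precedent available. Compound 4 is therefore estimated at 500 nM in this assay, expected to lie between 200 nM and 1500 nM.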

Compound 4, half-maximal inhibitory concentration: 80 nM
The estimate for compound 4 lay 6.3-fold (0.80 log units) above the measured number, outside the stated range (below it).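

In this assay, chloro in place of methyl on an aromatic carbon again strengthens inhibition, giving a 36-fold lower number from compound 3 to compound 4 (1.56 log units; beyond the scatter). For the compounds shown here, the direction of the change carried from one core to the other, but its size did not: the same change on two cores in this assay, a 6.2-fold lower number (0.79 log units; beyond the scatter) from compound 1 to compound 2 and a 36-fold lower number (1.56 log units; beyond the scatter) from compound 3 to compound 4, 5.8-fold (0.77 log units) apart, beyond the scatter of two such steps With only two pairs, this shows that the size of the step can depend on the core, but it does not show why, or how large the step would be on any further core.

The compounds shown leave open whether a bromo or a methoxy group in the same place would act as chloro does. Also open, from the compounds shown here alone, is whether the larger step would persist if an amine replaced the methanesulfonamido group.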